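Sulfonamide aryl swap on the pyridyl acrylamide series

This account rests on a few compounds, and the source may have more. Where it says the series, first, only, none or still open, it means among the compounds named here.

In a functional assay on HeLa cells (Homo sapiens) for inhibition, read by CCK-8 assay, with a stated time of 72 h (a lower number here means a stronger inhibitor, a higher number a weaker inhibitor), compound 1 `O=C(/C=C/c1cccnc1)NCCCc1ccc(S(=O)(=O)Nc2ccccc2)cc1` returns only a limit, > 10000 nM. Compound 2 `O=C(/C=C/c1cccnc1)NCCCCCc1cccc(S(=O)(=O)Nc2ccccc2)c1` gives 105 nM in this assay. Compound 3 `Cc1ccccc1NS(=O)(=O)c1cccc(CCCCCCNC(=O)/C=C/c2cccnc2)c1` gives 2.34 nM, the lower of the two actual numbers, and its gap to compound 2 lies well beyond the scatter. Compound 3 is therefore the reference point for the next step.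

Compound 4 `O=C(/C=C/c1cccnc1)NCCCCCCc1cccc(S(=O)(=O)Nc2ccc(F)cc2)c1` has 4-fluorophenyl in place of 2-methylphenyl on a sulfonamide nitrogen, and keeps the rest of compound 3 unchanged: 4-fluorophenyl in place of 2-methylphenyl on a sulfonamide nitrogen. Among the compounds with values here, no measured pair isolates a change at this place, since compound 2 and compound 3 differ in more than one place. With so little to go on, and with the remainder of compound 3 2.34 nM retained, no step beyond the scatter is expected in this assay, though a loss is more likely than a gain. The expected change is a 1.7-fold higher number from compound 3 to compound 4 (0.23 log units; within the scatter). Compound 4 is estimated at 4 nM, with an expected range of 1 nM to 25 nM.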

Compound 4, half-maximal inhibitory concentration: 99.9 nM
For compound 4 the middle estimate is 25-fold (1.40 log units) below the measured one; measured number outside the range, above it.
By their numbers in this assay, from the lowest: compound 3; then compounds 4 and 2 (each within the scatter of the next). At a limit, above all of these: compound 1.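

The aryl group on the sulfonamide nitrogen is a sensitive place in this assay: 4-fluorophenyl in place of 2-methylphenyl gives a 43-fold higher number from compound 3 to compound 4 (1.63 log units; beyond the scatter) with the rest of the molecule unchanged. That swap leaves the heavy-atom, hydrogen-bond donor and hydrogen-bond acceptor counts as they were, so those counts do not track the step. Nothing measured here bears on the cause of this step.

The swap changes both the substituent and where it sits on the ring, so the step cannot be assigned to either alone; 4-methylphenyl and 2-fluorophenyl on the same nitrogen would separate the two. Also open, as far as these compounds go, is whether other groups, such as 2-ethylphenyl or 2-methoxyphenyl, stay close to compound 3 at 2.34 nM in this assay or fall away from it.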